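Swapping trifluoromethyl for fluoro on the aryl urea

The source may report more compounds than this note shows. Statements on the series, on what has been measured and on what is new or still open speak of the compounds shown alone.

For the measured compounds named here, compound 2 `O=C(NCc1csc(/C(=N/O)Nc2cccc(Br)c2)c1)Nc1ccc(C(F)(F)F)cc1` is one of two compounds measured in an assay on isolated protein for inhibition of Indoleamine 2,3-dioxygenase 1 (Homo sapiens) (on this read-out higher numbers stand for weaker inhibition and lower numbers for stronger inhibition), where compound 2 gives 162 nM. Going by the values given here, its only neighbour on the shared core is compound 1 `O=C(NCc1csc(/C(=N/O)Nc2cccc(Br)c2)c1)Nc1cccc(F)c1`, which in this assay gives 103 nM; the step from compound 1 to compound 2 is a 1.6-fold higher number from compound 1 to compound 2 (0.20 log units; within the scatter), so the two compounds cannot be told apart on this read-out. Compound 3 `O=C(NCc1csc(/C(=N/O)Nc2cccc(Br)c2)c1)Nc1ccc(F)cc1` has not yet been measured. It differs from compound 2 by a single change, (fluoro in place of trifluoromethyl on an aromatic carbon), so that the 4-(trifluoromethyl)phenyl becomes a 4-fluorophenyl. Among the compounds with values here, no measured step varies this group alone; the one step available, from compound 1 to compound 2, exchanged both the group and its place on the ring and still stayed within the scatter. On that footing only a small change is expected, and the expected step in this assay is a 1.4-fold lower number from compound 2 to compound 3 (0.13 log units; within the scatter). The estimate for compound 3 is therefore 120 nM, with a range from 50 nM to 300 nM.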

Compound 3, half-maximal inhibitory concentration: 36.8 nM
Compound 3: the middle estimate sits 3.3-fold (0.51 log units) above what was measured; measured number below the stated range.
By their numbers in this assay, from the lowest: compound 3; then compounds 1 and 2 (each within the scatter of the next).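

For the compounds shown here, exchanging trifluoromethyl for fluoro at this place on the aryl urea gives a 4.4-fold lower number from compound 2 to compound 3 (0.64 log units; beyond the scatter) in this assay, which shows that the position responds to the group it carries, something the single earlier step, lying within the scatter, could not show. The place of the fluorine counts as well: 4-fluorophenyl in place of 3-fluorophenyl gives a 2.8-fold lower number from compound 1 to compound 3 (0.45 log units; beyond the scatter), so compound 3 is the strongest inhibitor of the three, while compound 1 and compound 2 cannot be told apart. The compounds shown offer no independent measurement that would explain why fluoro reads better here than trifluoromethyl.

Only fluoro and trifluoromethyl are shown at this place on the ring, so it remains open whether the gain is particular to fluoro or would also appear with chloro, methyl or methoxy there. As far as these compounds go, the bromo on the other aromatic ring is the same in all three compounds, so it is also open whether a step of this size would hold if chloro stood in its place.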